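The compounds below may be only part of what the source reports. "The series", "measured", "known", "first", "only" and "open" are said of these compounds alone.

Compound 1 `C=C1C(=O)O[C@H]2[C@H]1CC/C(COC(=O)CCC(=O)N1CCN(C(=O)Cn3cc(F)c(=O)[nH]c3=O)CC1)=C\CC[C@@]1(C)O[C@@H]21` gives only a limit, > 20000 nM, in a functional assay on Bel-7402 cells (Homo sapiens) for antiproliferative activity, read by MTT assay, with a stated time of 72 h; on this read-out higher numbers stand for weaker inhibition and lower numbers for stronger inhibition.
Compound 2 `C=C1C(=O)O[C@H]2[C@H]1CC/C(COC(=O)Cn1cc(F)c(=O)n(Cc3ccc(Cl)cc3)c1=O)=C\CC[C@@]1(C)O[C@@H]21` gives 2560 nM in this assay.

Compound 2 thus holds the only number shown; the other value sits at the limit of > 20000 nM in this assay, at which 1 of the 2 values shown sits. Compound 3 `C=C1C(=O)O[C@H]2[C@H]1CC/C(COC(=O)Cn1cc(F)c(=O)n(C)c1=O)=C\CC[C@@]1(C)O[C@@H]21` differs from compound 2 by hydrogen in place of 4-chlorophenyl on a saturated chain carbon bound to an aromatic nitrogen. For the measured compounds named here, no measured pair isolates this change, so the data offer no step to lean on. For compound 3 the expected step is a 3.1-fold higher number from compound 2 to compound 3 (0.49 log units; beyond the scatter), toward weaker inhibition. Compound 3 is accordingly estimated at 8000 nM, within a range from 2500 nM to 25000 nM, with a real chance that only a limit is reported.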

Compound 3, half-maximal inhibitory concentration: 9400 nM
The estimate for compound 3 lay 1.2-fold (0.07 log units) below the measured number, and the stated range covers the measured number.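

In this assay, for the compounds shown here, replacing 4-chlorophenyl with hydrogen on a saturated chain carbon bound to an aromatic nitrogen gives a 3.7-fold higher number from compound 2 to compound 3 (0.56 log units; beyond the scatter), the first step to isolate a single change and one that shows this position affects inhibition. The 4-chlorobenzyl to methyl change weakens inhibition without removing a measurable number, since compound 3 still gives 9400 nM. Nothing measured here accounts for this step.

On these data alone, whether the phenyl ring or its chlorine carries the difference remains open. A plain benzyl, a 4-methoxybenzyl or a longer alkyl chain at this place could separate the two, but none is among the compounds shown.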